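The source may report more compounds than this note shows. Statements on the series, on what has been measured and on what is new or still open speak of the compounds shown alone.

Of the compounds shown here, three have been measured in an assay on HeLa cells for inhibition of Indoleamine 2,3-dioxygenase 1 (Homo sapiens), read by spectrophotometry, with a stated time of 24 h; on this read-out higher numbers stand for an effect only at larger amounts of compound and lower numbers for an effect already at smaller amounts. Compound 1 `NS(=O)(=O)NNc1nonc1/C(=N/O)Nc1ccc(F)c(Br)c1` gives 101 nM. Compound 2 `[O-][S+]1CC(Nc2nonc2/C(=N/O)Nc2ccc(F)c(Br)c2)C1` gives 79 nM. Compound 3 `N=S1(=O)CC(Nc2nonc2/C(=N/O)Nc2ccc(F)c(Br)c2)C1` gives 53 nM. Compound 3 has the lowest number of the three, but all three lie within the scatter of each other: a 1.3-fold lower number from compound 1 to compound 2 (0.11 log units; within the scatter), a 1.9-fold lower number from compound 1 to compound 3 (0.28 log units; within the scatter) and a 1.5-fold lower number from compound 2 to compound 3 (0.17 log units; within the scatter). Each of these steps exchanges the group on a nitrogen on an aromatic ring while the rest of the shared core is kept.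

Compound 4 `CN(C)S(=O)(=O)CCNc1nonc1/C(=N/O)Nc1ccc(F)c(Br)c1` changes the same place: a group of 8 heavy atoms (4 carbon, 1 nitrogen, 2 oxygen, 1 sulfur; no ring) in place of a group of 6 heavy atoms (3 carbon, 1 nitrogen, 1 oxygen, 1 sulfur; one four-membered non-aromatic ring with 1 hetero atom), on a nitrogen on an aromatic ring. The measured steps bear on this only loosely, since they swap one substituent at that nitrogen for another, once a chain for a ring and once a ring for a ring, and none moved the number beyond the scatter. Compound 1 also carries a chain at this nitrogen, and its number lies within the scatter of compound 3. The expectation for compound 4 is therefore no step beyond the scatter in this assay, the estimated change being a 1.6-fold higher number from compound 3 to compound 4 (0.21 log units; within the scatter). Compound 4 is estimated at 85 nM, with a range from 35 nM to 200 nM.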

Compound 4, half-maximal effective concentration: 17 nM
The estimate for compound 4 lay 5.0-fold (0.70 log units) above the measured number; measured number below the stated range.
By their numbers in this assay, from the lowest: compound 4; then compounds 3, 2 and 1 (each within the scatter of the next).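

Going by these compounds alone, at this nitrogen on an aromatic ring, the substituent does move the number in this assay: 2-(dimethylsulfamoyl)ethyl gives a 3.1-fold lower number from compound 3 to compound 4 (0.49 log units; beyond the scatter), a 4.6-fold lower number from compound 2 to compound 4 (0.67 log units; beyond the scatter) and a 5.9-fold lower number from compound 1 to compound 4 (0.77 log units; beyond the scatter), the first steps at this place beyond the scatter. The result does not support a simple preference for a chain over a ring, as compound 1 also carries a chain at this nitrogen and goes against that reading by staying within the scatter of the two ring compounds. Nothing available accounts for the step.

The compounds shown do not separate the contribution of the two methyl groups on the sulfonamide nitrogen from that of the ethyl linker, a question that an unsubstituted sulfonamide or a methyl sulfone on the same chain, or a propyl linker, would address. Also open, from the compounds shown here alone, is how an amine or a carboxylic acid at the end of the chain would read at this nitrogen.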